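The source may hold more compounds than are shown below. What is called first, only, known or untested is meant among the compounds shown, and "the series" means these compounds.

Of the compounds shown here, three built on one shared core have been measured in an assay on CHO cells for binding affinity to metabotropic glutamate receptor 2 (Rattus norvegicus); on this read-out lower numbers stand for stronger inhibition and higher numbers for weaker inhibition. Compound 1 `N[C@]1(C(=O)O)[C@H]2[C@@H](C[C@H]1OCc1ccccc1)[C@]2(F)C(=O)O` gives 7.14 nM, compound 2 `N[C@]1(C(=O)O)[C@H]2[C@@H](C[C@H]1OCc1cccc(Cl)c1)[C@]2(F)C(=O)O` gives 3.28 nM, and compound 3 `N[C@]1(C(=O)O)[C@H]2[C@@H](C[C@H]1OCc1cccc(F)c1F)[C@]2(F)C(=O)O` gives 4.25 nM. Among these three numbers compound 3 holds the second highest, with compound 2 nearest and compound 1 furthest, yet both gaps lie within the scatter: a 1.3-fold higher number from compound 2 to compound 3 (0.11 log units; within the scatter) and a 1.7-fold lower number from compound 1 to compound 3 (0.23 log units; within the scatter). Among the measured compounds shown here, the only step that passed the scatter is a 2.2-fold lower number from compound 1 to compound 2 (0.34 log units; beyond the scatter), a modest move brought by a chloro in place of hydrogen on an aromatic carbon.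

Compound 4 `N[C@]1(C(=O)O)[C@H]2[C@@H](C[C@H]1OCc1ccc(F)c(Cl)c1)[C@]2(F)C(=O)O` differs from compound 3 in one place: 3-chloro-4-fluorophenyl in place of 2,3-difluorophenyl on a saturated chain carbon bound to an oxygen on a saturated carbon. The entering ring carries a chlorine, as the ring of compound 2 does, together with a single fluorine. Compound 4 thus shares the chloro of compound 2, so the step that bears on it most directly is a 2.2-fold lower number from compound 1 to compound 2 (0.34 log units; beyond the scatter), while a 1.3-fold higher number from compound 2 to compound 3 (0.11 log units; within the scatter) and a 1.7-fold lower number from compound 1 to compound 3 (0.23 log units; within the scatter) show that moving from one fluorinated ring to another did not carry the number beyond the scatter. The step from compound 3 to compound 4 is therefore expected to be small, a slight lowering of the number in this assay if any, and is estimated as a 1.3-fold lower number from compound 3 to compound 4 (0.11 log units; within the scatter). For compound 4 the expected value in this assay is 3.3 nM, with a range from 1.5 nM to 7.5 nM.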

Compound 4, inhibition constant: 3.57 nM
Compound 4: middle estimate off by 1.1-fold (0.03 log units), on the low side; the measured number falls inside the stated range.
By their numbers in this assay, from the lowest: compounds 2, 4, 3 and 1 (each within the scatter of the next, the first and the last beyond it).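

In this assay the added fluorine on the chlorinated ring gives a 1.1-fold higher number from compound 2 to compound 4 (0.04 log units; within the scatter) and so does not carry the number beyond the scatter, and the exchange of 2,3-difluorophenyl for 3-chloro-4-fluorophenyl, two rings of the same heavy-atom count with different halogens, gives a 1.2-fold lower number from compound 3 to compound 4 (0.08 log units; within the scatter) with the same outcome. Against the unsubstituted phenyl of compound 1, the new ring gives a 2.0-fold lower number from compound 1 to compound 4 (0.30 log units; within the scatter) and stays within the scatter, whereas the 3-chlorophenyl ring alone gave a 2.2-fold lower number from compound 1 to compound 2 (0.34 log units; beyond the scatter) and passed it, so compound 2 is the only one of the three halogenated compounds set apart from compound 1, while those three remain within the scatter of one another. Nothing available explains why these halogenated rings read so much alike.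

All the substituents on the ring shown here are halogens, which leaves open how a methoxy group, a nitrile or an amine on that ring would read in this assay. Also open, as far as these compounds go, is whether a longer chain between the oxygen and the aromatic ring would keep the number in this range.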